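The source may report more compounds than this note shows. Statements on the series, on what has been measured and on what is new or still open speak of the compounds shown alone.

Compound 1 `N#Cc1ccc(/C=C/S(=O)(=O)Cc2ccc(Nc3ncnc4ccccc34)cc2)cc1` is the starting point of this comparison. In a functional assay on MCF7 cells (Homo sapiens) (on this read-out lower numbers stand for stronger inhibition of growth and higher numbers for weaker inhibition of growth), compound 1 gives only a limit of the assay, > 100000 nM, rather than a number. Compound 2 `CC(C)(C)c1cc(/C=C/S(=O)(=O)Cc2ccc(Nc3ncnc4ccccc34)cc2)cc(C(C)(C)C)c1O` in this assay gives 13000 nM. Compound 3 `O=S(=O)(/C=C/c1ccc(Cl)cc1Cl)Cc1ccc(Nc2ncnc3ccccc23)cc1`, which carries 2,4-dichlorophenyl on a double-bonded chain carbon bound to a double-bonded chain carbon, gives 4000 nM in this assay. Compound 4 `O=S(=O)(/C=C/c1ccc(F)cc1F)Cc1ccc(Nc2ncnc3ccccc23)cc1` has not yet been measured. It differs from compound 1 as follows: 2,4-difluorophenyl in place of 4-cyanophenyl on a double-bonded chain carbon bound to a double-bonded chain carbon. Going by the values given here, the one measured step that bears on this change is the one from compound 1 to compound 3, an at least 25-fold lower number from compound 1 to compound 3 (1.39 log units; beyond the scatter), which swaps the same 4-cyanophenyl for a halogenated ring at the same place. Since compound 1 sits at the limit (the limit of > 100000 nM in this assay, at which 1 of the 3 values shown sits), the true size of that step is only known as a lower bound. For compound 4 an estimated step of an at least 10-fold lower number from compound 1 to compound 4 (1.00 log units; beyond the scatter), towards stronger inhibition of growth, is therefore expected, though the estimate for compound 4 is kept somewhat weaker than compound 3 because 4000 nM belongs to the dichloro ring and not to the difluoro ring. Compound 4 is thus expected to give about 10000 nM in this assay, with a range from 3000 nM to 40000 nM.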

Compound 4, concentration for 50% growth inhibition: > 100000 nM
Compound 4 gave a limit, no number; the forecaster's own chance of this, stated with the estimate: 15%; middle value at least 10-fold (1.00 log units) away from the limit.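

In this assay, the two halogenated rings do not behave alike at this place: 2,4-difluorophenyl in place of 2,4-dichlorophenyl gives an at least 25-fold higher number from compound 3 to compound 4 (1.39 log units; beyond the scatter), so the gain seen with compound 3 does not extend to every ring with two halogens. Replacing 4-cyanophenyl is therefore not enough on its own, and compound 4 gives only a limit of the assay, > 100000 nM. The step from compound 1 to compound 4 cannot be read, and the upper end of the assay now bounds a larger share of this small set: the limit of > 100000 nM in this assay, at which 2 of the 4 values shown sit.

The compounds shown leave open whether the gain of compound 3 is specific to chlorine or would also appear with bromine, methyl or trifluoromethyl on the same ring, and whether it needs both chlorines or a single one would do. They also leave open how far compound 1 and compound 4 actually lie beyond the limit, and so whether 4-cyanophenyl and 2,4-difluorophenyl differ at all in this assay.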